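From Methoxy to Amino: Does the Half-Life Hold?

The compounds below may be only part of what the source reports. "The series", "measured", "known", "first", "only" and "open" are said of these compounds alone.

In a physicochemical assay for metabolic stability, read by HPLC, in phosphate buffer, at pH 7.4, tested at 10 uM (a higher number here means that the compound lasts longer, a lower number that the compound disappears faster), compound 1 `COc1nc2ccccc2n1C(=O)NCCCCc1ccccc1` gives > 2 h, which is a limit of the assay and not a number. From the compounds shown here alone, compound 1 therefore stands at the limit of > 2 h in this assay, at which 1 of the 2 values shown sits, and its true half-life remains unknown. Compound 2 `O=C(NCCCCc1ccccc1)N1C(=O)c2ccccc2C1=O` gives 0.1 h in this assay. These two compounds differ in more than one place, so the data offer no measured single change to serve as a guide.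

Compound 3 `Nc1nc2ccccc2n1C(=O)NCCCCc1ccccc1` has not yet been measured. It departs from compound 1 by one change: amino in place of methoxy on an aromatic carbon. This is amino in place of methoxy on an aromatic carbon, between two ring nitrogen atoms, and the rest of the structure stays the same.

The expected change in this assay is an at least 1.3-fold lower number from compound 1 to compound 3 (0.12 log units; that floor lies within the scatter); a shorter half-life is the likelier direction, but the expected shift is small and may not go beyond the scatter. Among the measured compounds shown here, this expectation is uncertain, as its only anchor is compound 1 at > 2 h, a limit. For compound 3, the estimated half-life is 1.5 h, with an expected range of 0.4 h to 5 h.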

Compound 3, half-life: 0.233 h
Compound 3: middle estimate off by 6.4-fold (0.81 log units), on the high side; the whole stated range lies above it.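

Amino in place of methoxy on an aromatic carbon, between two ring nitrogen atoms, is the only single change here with a measured outcome, and in this assay it gives an at least 8.5-fold lower number from compound 1 to compound 3 (0.93 log units; beyond the scatter). This shows that altering this one group at this one place, with the rest of the structure unchanged, is enough to shift the half-life beyond the scatter, something the unrelated pair of compound 1 and compound 2 could not show. The step can be read only as a floor, and its true size stays unknown, because compound 1 is held by a limit of the assay and not by a number: the limit of > 2 h in this assay, at which 1 of the 3 values shown sits.

What the compounds shown leave open is whether this lower number belongs to the amino group in particular, or whether a methylamino group, a dimethylamino group or a plain hydrogen at the same place would give a similar result. Among the compounds shown here, also unanswered is whether the same exchange of methoxy for amino would carry over to a core other than the one shared by compound 1 and compound 3.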